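Removing the Methoxy Group from Compound 1

The source may report more compounds than this note shows. Statements on the series, on what has been measured and on what is new or still open speak of the compounds shown alone.

Compound 1 `COc1ccc(CCCCCCCCOc2ccc(CSCc3cccc(C(=O)O)c3)nc2/C=C/C(=O)O)cc1` holds the lowest number among the three measured compounds: in a functional assay on the whole organism with Homo sapiens as the target, read by calcium flux (a lower number here means a stronger inhibitor, a higher number a weaker inhibitor), compound 1 gives 131 nM. Compound 2 `COc1ccc(CCCCCCCCOc2ccc(CSCc3cccc(C(=O)O)c3)nc2CCC(=O)O)cc1` gives 240 nM, and the step of a 1.8-fold higher number from compound 1 to compound 2 (0.26 log units; within the scatter) stays within the scatter. Compound 3 `COc1ccc(CCCCCCCCOc2ccc(CSCc3ccccc3C(=O)O)nc2/C=C/C(=O)O)cc1` gives 710 nM, so that a 5.4-fold higher number from compound 1 to compound 3 (0.73 log units; beyond the scatter) amounts to a modest loss.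

Compound 4 `O=C(O)/C=C/c1nc(CSCc2cccc(C(=O)O)c2)ccc1OCCCCCCCCc1ccccc1` has not yet been measured. It differs from compound 1 by hydrogen in place of methoxy on an aromatic carbon. Neither measured step bears directly on this change. The step to compound 2 alters the 2-carboxyethenyl group on the core, and the step to compound 3 exchanges 3-carboxyphenyl for 2-carboxyphenyl; the methoxy-bearing ring is untouched in both. The measured compounds therefore give no direct guide to the size of this step. The change removes only the methoxy group, and a shift of modest size rather than a large one is expected, with a lean toward a slight loss, so that a 1.7-fold higher number from compound 1 to compound 4 (0.23 log units; within the scatter) is the expected outcome. Compound 4 is accordingly estimated to give 220 nM in this assay, with an expected range from 70 nM to 700 nM.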

Compound 4, half-maximal inhibitory concentration: 320 nM
Beside the measured number, compound 4's estimate is 1.5-fold (0.16 log units) below it; the range from low to high includes it.
By their numbers in this assay, from the lowest: compounds 1, 2 and 4 (each within the scatter of the next, the first and the last beyond it); then compound 3.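

In this assay, among the compounds shown here, the exchange of methoxy for hydrogen gives a 2.4-fold higher number from compound 1 to compound 4 (0.39 log units; beyond the scatter), the first reading of any change on the 4-methoxyphenyl end of the molecule, which both earlier steps left untouched. The step shows that this end is not silent: going from 4-methoxyphenyl to phenyl, at a place para to a large group, brings a modest loss that lies beyond the scatter. At the same time, the loss remains modest, so the methoxy group is not needed for compound 4 to register as an inhibitor in this assay, and no measurement shown here explains the size of the step.

The compounds shown leave open whether another group at this place, such as a fluorine atom, a hydroxyl or an ethoxy group, would match compound 1 or give a lower number than the methoxy group does. They also leave open whether the same exchange of methoxy for hydrogen would cost as much when made on compound 2 or on compound 3, where the rest of the molecule differs.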